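The compounds below may be only part of what the source reports. "The series", "measured", "known", "first", "only" and "open" are said of these compounds alone.

Measured compounds:
- compound 1, `CC(=O)Nc1ccc(C2=NNC(=O)CC2)cc1`: 1 ug/mL in a functional assay for inhibition, with Homo sapiens as the target; a higher number here means that more compound is needed for the effect, a lower number that less compound is needed
- compound 2, `CN1N=C(c2ccc(N)cc2)CCC1=O`: in this assay compound 2 reaches only > 46.4 ug/mL, which is a limit of the assay and not a number the limit of > 46.4 ug/mL in this assay, at which 1 of the 3 values shown sits.
- compound 3, `CC1CC(c2ccc(N)cc2)=NNC1=O`: compound 3 gives 43.8 ug/mL in this assay

Compound 1 stands lowest of the two numbers shown; the nearest number, that of compound 3, lies a long way higher, well beyond the scatter, so compound 1 needs the least compound of the set. The core is shared by all three; compound 1 carries an acetamide on the aryl ring where compound 3 carries the free amine.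

Compound 4, `CC(C)NCC(=O)Nc1ccc(C2=NNC(=O)CC2)cc1`, has not yet been measured in this assay. It differs from compound 1 in one place: isopropylamino in place of hydrogen on a saturated chain carbon bound to a carbonyl carbon. Among the measured compounds shown here, no step between measured compounds touches this part of the molecule, so the expected size of the step rests on the structural change alone. The acetamide of compound 1 is kept, and the isopropylamino group is added on its saturated chain carbon; a step of modest size is expected, with no firm direction, most likely a slight rise in the number.

The estimate for compound 4 is 2 ug/mL, with a range from 0.5 ug/mL to 8 ug/mL, and the expected step is a 2.0-fold higher number from compound 1 to compound 4 (0.30 log units; within the scatter).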

Compound 4, half-maximal effective concentration: about 46.4 ug/mL
Compound 4: the middle estimate sits 23-fold (1.37 log units) below what was measured, and the stated range ends below it.
By their numbers in this assay, from the lowest: compound 1; then compounds 3 and 4 (each within the scatter of the next).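

In this assay, isopropylamino in place of hydrogen on a saturated chain carbon bound to a carbonyl carbon gives a 46-fold higher number from compound 1 to compound 4 (1.67 log units; beyond the scatter). Among the compounds shown here, this is the first step to touch this position, and it shows that the low number of compound 1 does not survive this substitution on the acetyl part of the molecule. Since the shared core and the amide link are unchanged, the whole rise goes with this single change. For compound 2 the reading is a limit of the assay and not a number, so it offers no measure of the upper end of the series: the limit of > 46.4 ug/mL in this assay, at which 1 of the 4 values shown sits.

Going by these compounds, whether the rise belongs to the amine nitrogen or to the added carbons stays open, and a methyl, a methoxy or a hydroxyl group on the same saturated chain carbon would separate the two. On these data alone, with a single substituent at this position, it also stays open whether an unsubstituted amino group, a carboxylic acid or a longer chain in its place would give a number nearer that of compound 1.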